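Swapping pyrrolidin-2-yl for pyrrolidin-3-yl

The source may hold more compounds than are shown below. What is called first, only, known or untested is meant among the compounds shown, and "the series" means these compounds.

In a physicochemical assay for solubility (a lower number here means a less soluble compound, a higher number a more soluble compound), compound 1 `CC(C)(C)OC(=O)N1CCC[C@H]1C(=O)N1CCC(NS(=O)(=O)c2cc(S(=O)(=O)c3ccccc3)ccc2C(F)(F)F)CC1` gives 25000 nM and compound 2 `CC(C)(C)OC(=O)N1CCC[C@@H]1C(=O)N1CCC(NS(=O)(=O)c2cc(S(=O)(=O)c3ccccc3)ccc2C(F)(F)F)CC1` gives 25000 nM, so compound 2 stands level with compound 1. Within the data shown here, the only measured step, no change at the digits printed from compound 1 to compound 2 (within the scatter), offers a weak guide here, given (the fact that compounds 1 and 2 differ only in the configuration as drawn). Compound 3 `CC(C)(C)OC(=O)N1CC[C@H](C(=O)N2CCC(NS(=O)(=O)c3cc(S(=O)(=O)c4ccccc4)ccc3C(F)(F)F)CC2)C1` carries a different change, 1-(tert-butoxycarbonyl)pyrrolidin-3-yl in place of 1-(tert-butoxycarbonyl)pyrrolidin-2-yl on a carbonyl carbon. Resting only on compound 2 at 25000 nM, the expected step in this assay is no change at the digits printed from compound 2 to compound 3 (within the scatter), with none expected beyond the scatter. For compound 3 the estimated value is 25000 nM, with an expected range of 12000 nM to 40000 nM.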

Compound 3, solubility: 25000 nM
Estimate against measurement, compound 3: no gap at the digits printed; the range from low to high includes it.
By their numbers in this assay, from the lowest: compounds 1, 2 and 3 (each within the scatter of the next).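

Earlier, only the drawn configuration differed; here the point of attachment on the ring differs too, with 1-(tert-butoxycarbonyl)pyrrolidin-3-yl in place of 1-(tert-butoxycarbonyl)pyrrolidin-2-yl on the carbonyl carbon. In this assay the result is no change at the digits printed from compound 2 to compound 3 (within the scatter) and likewise no change at the digits printed from compound 1 to compound 3 (within the scatter), so neither attachment point stands apart from the other in this read-out. Nothing available bears on why these compounds read alike.

All three compounds carry the tert-butoxycarbonyl group. On these data alone, whether a free amine in its place, or a carboxylic acid on the carbonyl carbon, would read differently in this assay remains open.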